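Removing a Protecting Group Across Two Anilide Cores

A few compounds are considered here, and "the series" means these few. Any claim that something is new, unique, unknown or untested is made for them only; others in the source may bear on it.

Measured compounds:
Compound 1 `CC(C)C[C@H](NC(=O)c1cc(Cl)ccc1OCCNC(=O)OC(C)(C)C)C(=O)Nc1ccc([N+](=O)[O-])cc1Cl` — > 10000 nM
Compound 2 `CC(C)C[C@H](NC(=O)c1cc(Cl)ccc1OCCN)C(=O)Nc1ccc([N+](=O)[O-])cc1Cl` — > 10000 nM
Compound 3 `CC(C)[C@H](NC(=O)c1cc(Cl)ccc1OCCNC(=O)OC(C)(C)C)C(=O)Nc1cc(C(F)(F)F)cc(C(F)(F)F)c1` — > 10000 nM

The three measured compounds were tested in a functional assay on MDA-MB-231 cells (Homo sapiens) for inhibition, read by MTT assay, with a stated time of 72 h; on this read-out higher numbers stand for weaker inhibition and lower numbers for stronger inhibition. Compound 1 gives > 10000 nM, which is a limit of the assay rather than a number. Compound 2 likewise gives > 10000 nM, again a limit. The change between them, (hydrogen in place of tert-butoxycarbonyl on an amine nitrogen), therefore yields a step that the two limits leave unreadable from compound 1 to compound 2. Compound 3 gives > 10000 nM, also a limit, so that (the limit of > 10000 nM in this assay, at which 3 of the 3 values shown sit). The difference between the cores of compound 1 and compound 3 is not broken down here.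

Compound 4 `CC(C)[C@H](NC(=O)c1cc(Cl)ccc1OCCN)C(=O)Nc1cc(C(F)(F)F)cc(C(F)(F)F)c1` is not yet measured. It differs from compound 3 by hydrogen in place of tert-butoxycarbonyl on an amine nitrogen, the same change that turns compound 1 into compound 2. Since compound 1 and compound 3 both sit at the limit, the step is expected to be a step that the limit leaves unreadable from compound 3 to compound 4. Compound 4 is therefore estimated at 15000 nM in this assay.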

Compound 4, half-maximal inhibitory concentration: 5430 nM
Compound 4: the middle estimate sits 2.8-fold (0.44 log units) above what was measured, and the stated range covers the measured number.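

In this assay, putting hydrogen in place of tert-butoxycarbonyl on the core of compound 3 gives an at least 1.8-fold lower number from compound 3 to compound 4 (0.26 log units; that floor lies within the scatter), and since that floor lies within the usual scatter, a real gain is possible but not shown. The value of compound 3, > 10000 nM, is a limit. The same change on the core of compound 1 cannot be read, so nothing shows that the change carries from one core to the other: the limit of > 10000 nM in this assay, at which 3 of the 4 values shown sit.

Going by these compounds, whether the size of this step depends on the core stays open. Also open, on these data alone, is how a longer amine chain or a carboxylic acid in place of 2-aminoethyl would behave in this assay.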